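The source may hold more compounds than are shown below. What is called first, only, known or untested is meant among the compounds shown, and "the series" means these compounds.

Three compounds have been measured in a functional assay on A549 cells (Homo sapiens) for inhibition, read by sulforhodamine B assay; a lower number here means a stronger inhibitor of growth, a higher number a weaker inhibitor of growth:

compound 1, `O=C1NC(=S)S/C1=C\c1cc(-c2ccccc2)ccc1OCc1ccccc1`, with 4000 nM;
compound 2, `CC(C)(C)c1ccc(-c2ccc(OCc3ccccc3)c(/C=C3\SC(=S)NC3=O)c2)cc1`, with 2000 nM;
compound 3, `O=C1NC(=O)/C(=C/c2cc(-c3ccccc3)ccc2OCc2ccccc2)S1`, with 2000 nM.

Compound 1 and compound 2 share a core and differ in one place: tert-butyl in place of hydrogen on an aromatic carbon. In this assay this change gave a 2.0-fold lower number from compound 1 to compound 2 (0.30 log units; within the scatter). Compound 3 differs from compound 1 in another group, so the two cores are not the same: a group of 8 heavy atoms (4 carbon, 1 nitrogen, 2 oxygen, 1 sulfur; one five-membered non-aromatic ring with 2 hetero atoms) in place of a group of 8 heavy atoms (4 carbon, 1 nitrogen, 1 oxygen, 2 sulfur; one five-membered non-aromatic ring with 2 hetero atoms), on an aromatic carbon. That change gave a 2.0-fold lower number from compound 1 to compound 3 (0.30 log units; within the scatter). Compound 2 and compound 3 stand level with each other within the usual scatter, and compound 1 is separated from both by a step that also stays within it.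

Compound 4, `CC(C)(C)c1ccc(-c2ccc(OCc3ccccc3)c(/C=C3\SC(=O)NC3=O)c2)cc1`, has not yet been measured. It carries the core of compound 3 and differs from it in one place: tert-butyl in place of hydrogen on an aromatic carbon. For the measured compounds named here, this is the same change as the one from compound 1 to compound 2, with the same group leaving, the same group entering and the same surroundings around the place. Going by the values given here, only that one earlier example supports any expectation, and it stayed within the scatter. The step from compound 3 to compound 4 in this assay is therefore expected to be small, about a 1.7-fold lower number from compound 3 to compound 4 (0.22 log units; within the scatter), resting on a 2.0-fold lower number from compound 1 to compound 2 (0.30 log units; within the scatter). Compound 4 is accordingly estimated at 1200 nM, most likely between 500 nM and 3000 nM.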

Compound 4, concentration for 50% growth inhibition: 2000 nM
Beside the measured number, compound 4's estimate is 1.7-fold (0.22 log units) below it; the measured number falls inside the stated range.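

In this assay, tert-butyl on the core of compound 3 gave no change at the digits printed from compound 3 to compound 4 (within the scatter), and this result agrees with the earlier example of the same change: the same change on two cores in this assay, a 2.0-fold lower number (0.30 log units; within the scatter) from compound 1 to compound 2 and no change at the digits printed (within the scatter) from compound 3 to compound 4, 2.0-fold (0.30 log units) apart, within the scatter of two such steps The exchange of the five-membered non-aromatic ring, now read on the two compounds that carry tert-butyl, gave no change at the digits printed from compound 2 to compound 4 (within the scatter), and this also agrees with its earlier example: the same change on two cores in this assay, a 2.0-fold lower number (0.30 log units; within the scatter) from compound 1 to compound 3 and no change at the digits printed (within the scatter) from compound 2 to compound 4, 2.0-fold (0.30 log units) apart, within the scatter of two such steps Neither change therefore behaved measurably differently on the second core, but every step here lies within the scatter, so the four compounds show neither that either change truly alters growth inhibition nor that the two changes add up, and a real effect too small to separate from the scatter cannot be excluded.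

The compounds shown leave open whether a different group in place of tert-butyl, such as an amine, a carboxylic acid or a longer chain, would give a step beyond the scatter on either core. They also leave open whether the same agreement between cores would hold for such a group, since each comparison here rests on a single pair of steps.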